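Extending the Fatty Chain on a Triacid Amide

The compounds below may be only part of what the source reports. "The series", "measured", "known", "first", "only" and "open" are said of these compounds alone.

Compound 1 `CCCCCCCCCCCCCC(=O)NC(CCC(=O)O)(CCC(=O)O)CCC(=O)O` joins a long saturated chain through an amide to a core bearing three carboxylic acids. In an ADME assay on cells (Epithelial cell, Homo sapiens) for cytotoxicity, read by MTT assay (on this read-out lower numbers stand for an effect already at smaller amounts and higher numbers for an effect only at larger amounts of compound), compound 1 gives 300000 nM, the smaller of the two numbers in hand, though the gap to its neighbour stays within the usual scatter. Compound 2 `CCCCCCCCCCCCCCCCCCOC(=O)NC(CCC(=O)O)(CCC(=O)O)CCC(=O)O`, which ties a longer chain to the same core through a carbamate, gives 350000 nM. Compound 3 `CCCCCCCCCCCCCCCC(=O)NC(CCC(=O)O)(CCC(=O)O)CCC(=O)O` introduces (ethyl in place of hydrogen on a saturated chain carbon, ten or more bonds along the chain from a carbonyl carbon). For the measured compounds named here, with no measured step to guide this change, the step of a 1.1-fold lower number from compound 1 to compound 3 (0.05 log units; within the scatter) is expected to stay within the scatter. Compound 3 is therefore estimated at 270000 nM, with a likely range from 130000 nM to 550000 nM.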

Compound 3, half-maximal effective concentration: 940000 nM
Beside the measured number, compound 3's estimate is 3.5-fold (0.54 log units) below it, outside the stated range (above it).
By their numbers in this assay, from the lowest: compounds 1 and 2 (each within the scatter of the next); then compound 3.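

Ethyl in place of hydrogen on a saturated chain carbon is not a silent change: in this assay it gives a 3.1-fold higher number from compound 1 to compound 3 (0.50 log units; beyond the scatter) and so moves the effect to larger amounts of compound. Even this far along the chain, with the amide and shared core unchanged, a small addition can shift the read-out. No measurement here explains the shift.
From the compounds shown here alone, whether a longer chain would shift the read-out further remains open. So does the effect of an amine or hydroxyl group at this place.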